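Benzyloxy added to a bis-chalcone: expected cytotoxicity

The source may hold more compounds than are shown below. What is called first, only, known or untested is meant among the compounds shown, and "the series" means these compounds.

Of the compounds shown here, two of a shared core have been tested for their effect on the viability of human kidney cells. In an ADME assay on HEK293 cells (Homo sapiens) for cytotoxicity, read by MTT assay, with a stated time of 24 h (on this read-out lower numbers stand for stronger inhibition and higher numbers for weaker inhibition), compound 1 `Cc1cc(O)c(C(=O)/C=C/c2ccc(Cl)cc2)c(-c2ccccc2)c1C(=O)/C=C/c1ccc(Cl)cc1` gives 10000 nM, the lowest of the two numbers that have been measured. Its nearest neighbour, compound 2 `Cc1cc(O)c(C(=O)/C=C/c2ccc(F)cc2)c(-c2ccc(Br)cc2)c1C(=O)/C=C/c1ccc(F)cc1`, gives 20000 nM in this assay, a value that lies within the scatter of compound 1, so the two cannot be told apart on these numbers alone. For the measured compounds named here, no pair of measured compounds differs in only one place, so no single structural change has yet been tied to a shift in this assay.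

Compound 3 `Cc1cc(O)c(C(=O)/C=C/c2ccc(Cl)cc2)c(-c2ccc(OCc3ccccc3)cc2)c1C(=O)/C=C/c1ccc(Cl)cc1` has not been measured. It differs from compound 1 by benzyloxy in place of hydrogen on an aromatic carbon. Going by the values given here, with no comparable step among the measured compounds, no step beyond the scatter is expected from compound 1 to compound 3; the estimated shift is a 1.1-fold lower number from compound 1 to compound 3 (0.05 log units; within the scatter). On this basis compound 3 is expected to give about 9000 nM in this assay, with a likely range from 3000 nM to 25000 nM.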

Compound 3, half-maximal inhibitory concentration: "not active" (no number reported)
The entry for compound 3 holds no number; no gap can be computed for the estimate.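

For the compounds shown here, compound 3 is entered as "not active" with no number, so no step from compound 1 to compound 3 can be read. No other data at hand bear on this result. The compounds shown leave open how far benzyloxy in place of hydrogen on the aromatic carbon shifts the number in this assay.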